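This account rests on a few compounds, and the source may have more. Where it says the series, first, only, none or still open, it means among the compounds named here.

Measured so far in a functional assay on MDA-MB-231 cells (Homo sapiens) for antiproliferative activity, read by sulforhodamine B assay, with a stated time of 48 h; a higher number here means a weaker inhibitor, a lower number a stronger inhibitor:
compound 1 `O=S(=O)(Nc1ccccn1)c1ccc(N/C(S)=N\c2ccnc3cc(C(F)(F)F)ccc23)cc1`: 49300 nM
compound 2 `Cc1ccnc(NS(=O)(=O)c2ccc(N/C(S)=N\c3ccnc4cc(C(F)(F)F)ccc34)cc2)n1`: 29800 nM

Compound 2 holds the lower of the two numbers, yet its gap to compound 1 stays within the scatter: a 1.7-fold lower number from compound 1 to compound 2 (0.22 log units; within the scatter). Compound 3 `COc1ncnc(NS(=O)(=O)c2ccc(N/C(S)=N\c3ccnc4cc(C(F)(F)F)ccc34)cc2)c1OC` is not yet measured; it carries 5,6-dimethoxypyrimidin-4-yl in place of 4-methylpyrimidin-2-yl on a sulfonamide nitrogen. For the measured compounds named here, the only step bearing on this change is the earlier swap at the same sulfonamide nitrogen, which did not move the number beyond the scatter, so no step beyond the scatter is expected here either in this assay. Compound 3 is expected to give 30000 nM, within 10000 nM to 90000 nM. That expectation amounts to a step of a 1.0-fold higher number from compound 2 to compound 3 (0.00 log units; within the scatter).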

Compound 3, half-maximal inhibitory concentration: 83000 nM
Compound 3: the middle estimate sits 2.8-fold (0.44 log units) below what was measured, within the range that was stated.
By their numbers in this assay, from the lowest: compounds 2, 1 and 3 (each within the scatter of the next, the first and the last beyond it).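

In this assay the sulfonamide nitrogen turns out to tolerate a step beyond the scatter: 5,6-dimethoxypyrimidin-4-yl in place of 4-methylpyrimidin-2-yl gives a modest change (a 2.8-fold higher number from compound 2 to compound 3 (0.44 log units; beyond the scatter)), the first here to pass the scatter. In place of pyridin-2-yl, the same group stays within it (a 1.7-fold higher number from compound 1 to compound 3 (0.23 log units; within the scatter)), so the effect of this change depends on the group replaced. No measurement available here bears on what lies behind this step.

On these data alone, whether both methoxy groups are needed for the step remains open. So does the effect of an amine or a carboxylic acid on the pyrimidine ring at this sulfonamide nitrogen.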